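The source may hold more compounds than are shown below. What is called first, only, known or untested is meant among the compounds shown, and "the series" means these compounds.

Compound 1 `CCCc1ccc(-c2cc(=O)c3c(o2)C(CC)(CC)C(=O)C(CC)=C3O)cc1`: in a functional assay on KB cells (Homo sapiens) for antiproliferative activity, read by sulforhodamine B assay, with a stated time of 3 days (a higher number here means that more compound is needed for the effect, a lower number that less compound is needed), compound 1 gives > 53 uM, which is a limit of the assay rather than a number.
Compound 2 `CCC1=C(O)c2c(oc(-c3ccc(C(C)C)cc3)cc2=O)C(CC)(CC)C1=O`: in this assay compound 2 gives 8.13 uM.
Compound 3 `CCC1=C(O)c2c(oc(-c3ccc(F)cc3)cc2=O)C(CC)(CC)C1=O`: in this assay compound 3 gives 33 uM.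

All three share one core and differ only in the substituent on the phenyl ring attached to it. For compound 1 only a limit is known (the limit of > 53 uM in this assay, at which 1 of the 3 values shown sits), so its true number could lie anywhere beyond that point. The unmeasured compound 4 `CCC1=C(O)c2c(oc(-c3ccc(C)c(C)c3)cc2=O)C(CC)(CC)C1=O` differs from compound 1 in one place: 3,4-dimethylphenyl in place of 4-propylphenyl on an aromatic carbon. Two measured steps start from compound 1. Replacing the propyl chain by isopropyl gave an at least 6.5-fold lower number from compound 1 to compound 2 (0.81 log units; beyond the scatter), whereas replacing it by fluoro gave an at least 1.6-fold lower number from compound 1 to compound 3 (0.20 log units; that floor lies within the scatter); between those two products lies a 4.1-fold higher number from compound 2 to compound 3 (0.61 log units; beyond the scatter). In compound 4 the carbons sit as two methyls rather than one chain, which resembles the isopropyl case, so the step is expected to go downward and beyond the scatter, about an at least 3.5-fold lower number from compound 1 to compound 4 (0.54 log units; beyond the scatter). Compound 4 is therefore estimated at 15 uM, within 5 uM to 55 uM.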

Compound 4, concentration for half-maximal effect: 35.5 uM
Estimate against measurement, compound 4: 2.4-fold (0.37 log units) below, within the range that was stated.
By their numbers in this assay, from the lowest: compound 2; then compounds 3 and 4 (each within the scatter of the next). At a limit, above all of these: compound 1.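

In this assay, carbon on the phenyl ring does not by itself give a low number: 3,4-dimethylphenyl falls short of 4-isopropylphenyl, with a 4.4-fold higher number from compound 2 to compound 4 (0.64 log units; beyond the scatter), so among the compounds shown the low number goes with the isopropyl group of compound 2, and compound 4 goes against any wider rule about alkyl groups. The two methyls and the single fluoro cannot be told apart here, with a 1.1-fold higher number from compound 3 to compound 4 (0.03 log units; within the scatter). The step from compound 1, an at least 1.4-fold lower number from compound 1 to compound 4 (0.17 log units; that floor lies within the scatter), gives only a floor and cannot be read as a size, since compound 1 stands at a limit: the limit of > 53 uM in this assay, at which 1 of the 4 values shown sits.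

From the compounds shown here alone, whether another branched group such as tert-butyl would match isopropyl remains open. So does the effect of an amine or a carboxylic acid on the phenyl ring.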